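From compound 3 to compound 4: an expected step

This account rests on a few compounds, and the source may have more. Where it says the series, first, only, none or still open, it means among the compounds named here.

Measured in a functional assay on HCT-116 cells (Homo sapiens) for inhibition, read by MTT assay, with a stated time of 72 h; a lower number here means a stronger inhibitor, a higher number a weaker inhibitor:
- compound 1 `O=C(CCCCCCCN(Cc1ccc(F)cc1)c1ncc(C(=O)NCCCn2ccnc2)s1)NO`: 63000 nM
- compound 2 `CC(C)CCN(CCCCCC(=O)NO)c1ncc(C(=O)NCCCn2ccnc2)s1`: 85000 nM
- compound 3 `O=C(/C=C/c1ccc(CN(Cc2ccc(F)cc2)c2ncc(C(=O)NCCCn3ccnc3)s2)cc1)NO`: 83000 nM

Compound 3 stands level with compound 1 and compound 2, within the scatter of both. Compound 4 `O=C(CCCCCCN(Cc1ccc(F)cc1)c1ncc(C(=O)NCCCn2ccnc2)s1)NO` differs from compound 3 as follows: 5-(hydroxycarbamoyl)pentyl in place of 4-(2-(hydroxycarbamoyl)ethenyl)phenyl on a saturated chain carbon bound to a nitrogen on an aromatic ring. In words, 5-(hydroxycarbamoyl)pentyl replaces 4-(2-(hydroxycarbamoyl)ethenyl)phenyl. Among the measured compounds shown here, the one measured step bearing on this is a 1.3-fold higher number from compound 1 to compound 3 (0.12 log units; within the scatter), where that same phenyl group replaced 6-(hydroxycarbamoyl)hexyl, and it stayed within the scatter. No step beyond the scatter is therefore expected in this assay. The expected step is a 1.2-fold lower number from compound 3 to compound 4 (0.07 log units; within the scatter). Compound 4 is estimated at 70000 nM, with an expected range of 35000 nM to 130000 nM.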

Compound 4, half-maximal inhibitory concentration: 9700 nM
The estimate for compound 4 lay 7.2-fold (0.86 log units) above the measured number, and the stated range ends above it.
By their numbers in this assay, from the lowest: compound 4; then compounds 1, 3 and 2 (each within the scatter of the next).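

In this assay, the place on a saturated chain carbon bound to a nitrogen on an aromatic ring responds to the exact group it carries: 5-(hydroxycarbamoyl)pentyl in place of 4-(2-(hydroxycarbamoyl)ethenyl)phenyl gives an 8.6-fold lower number from compound 3 to compound 4 (0.93 log units; beyond the scatter), a step beyond the scatter. The earlier swap at this place did not show this, and the shorter 5-(hydroxycarbamoyl)pentyl chain in place of 6-(hydroxycarbamoyl)hexyl gives a 6.5-fold lower number from compound 1 to compound 4 (0.81 log units; beyond the scatter), so chain length alone shifts the number. Nothing at hand explains these steps. Going by these compounds, whether a still shorter 4-(hydroxycarbamoyl)butyl chain lowers the number further remains open, as does whether a carboxylic acid can stand in for the hydroxycarbamoyl end.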